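This account rests on a few compounds, and the source may have more. Where it says the series, first, only, none or still open, it means among the compounds named here.

Measured compounds:
compound 1 `CCSc1nnc(Cc2ccccc2Oc2ccccc2)[nH]1` gives 142%
compound 2 `CCCSc1nnc(Cc2ccc(Cl)cc2Oc2ccccc2Cl)[nH]1` gives 125%
compound 3 `CCCSc1nnc(Cc2ccc(Cl)cc2Oc2ccccc2F)[nH]1` gives 127%

In a functional assay on the whole organism (strain NMRI) with Mus musculus as the target, with a stated time of 60 min, at a dose of 10 mg/kg by the intraperitoneal route (a lower number here means a weaker effect, a higher number a stronger effect of the compound at the dose given), compound 1 gives 142%, the highest of the three numbers; compound 3 lies below it by a gap beyond the scatter, and compound 2 lies further below, again beyond the scatter. Compound 4 `CCOc1nnc(Cc2ccccc2Oc2ccccc2)[nH]1` differs from compound 1 by ethoxy in place of ethylsulfanyl on an aromatic carbon. Among the measured compounds shown here, the only measured step, a number 2 percentage points higher from compound 2 to compound 3 (within the scatter), touches a different part of the molecule and so gives no guide to this exchange; no measured pair replaces ethylsulfanyl by ethoxy here. Compound 4 is therefore expected to change by a number 14 percentage points lower from compound 1 to compound 4 (beyond the scatter), a step that may or may not exceed the scatter. Compound 4 is estimated at 128%, within 100% to 155%.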

Compound 4, a percentage reported as activity, at one dose (the size of the read-out at that dose, not a potency): 126%
For compound 4 the middle estimate is 2 percentage points above the measured one; the measured number falls inside the stated range.
By their numbers in this assay, from the lowest: compounds 2, 4 and 3 (each within the scatter of the next); then compound 1.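

In this assay, among the compounds shown here, ethoxy in place of ethylsulfanyl on the aromatic carbon between two ring nitrogen atoms gives a number 16 percentage points lower from compound 1 to compound 4 (beyond the scatter) and is the first step read at this position. The read-out here therefore depends on the atom that links this group to the core, even though the heavy-atom count and hydrogen-bond counts stay the same. Nothing available explains this step.

As far as these compounds go, whether an amine or a propoxy chain at this position would hold the number stays open. So does whether the same exchange would give a similar step on the core of compound 3.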